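This account rests on a few compounds, and the source may have more. Where it says the series, first, only, none or still open, it means among the compounds named here.

Measured so far:
compound 1 `CCCc1nnc(O)n2c(CCC)nc(C)c12` — 16000 nM
compound 2 `CCCc1nnc(SC)n2c(CCC)nc(C)c12` — > 48000 nM

Compound 2 stands at a limit in a functional assay for inhibition, with Homo sapiens as the target; on this read-out higher numbers stand for weaker inhibition and lower numbers for stronger inhibition: its value of > 48000 nM is a limit of the assay and not a number, so compound 2 sits at the limit of > 48000 nM in this assay, at which 1 of the 2 values shown sits. For the measured compounds named here, the one measured step, an at least 3.0-fold higher number from compound 1 to compound 2 (0.47 log units; beyond the scatter), places compound 2 weaker than compound 1, which gives 16000 nM in this assay.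

Compound 3 `CCCc1nnc(S)n2c(CCC)nc(C)c12` is not yet measured. It differs from compound 2 by hydrogen in place of methyl on a sulfur whose other neighbour is an aromatic carbon; cut one bond further out, the change reads methylsulfanyl to sulfanyl. Going by the values given here, the only step that bears on it is an at least 3.0-fold higher number from compound 1 to compound 2 (0.47 log units; beyond the scatter), in which methylsulfanyl replaced hydroxy; removing the methyl from that sulfur undoes part of that change, so a number for compound 3 between those of compound 1 and compound 2 is expected, with a fair chance that this assay again reports only a limit. The step of an at least 1.6-fold lower number from compound 2 to compound 3 (0.20 log units; that floor lies within the scatter) is the expected size. Compound 3 is expected to give about 30000 nM in this assay, within 10000 nM to 100000 nM.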

Compound 3, half-maximal inhibitory concentration: > 48000 nM
Compound 3 ended at the assay's limit; the forecaster's own chance of this, stated with the estimate: 45%; middle value at least 1.6-fold (0.20 log units) away from the limit.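

In this assay, sulfanyl on the aromatic carbon does not keep the level of hydroxy, with an at least 3.0-fold higher number from compound 1 to compound 3 (0.47 log units; beyond the scatter). Both sulfur groups at this position, methylsulfanyl and sulfanyl, therefore read weaker than hydroxy, and taking the methyl off the sulfur does not bring the reading back into the measurable range. Compound 3 gives > 48000 nM, which is a limit of the assay and not a number, and it shares that limit with compound 2, so the step between these two cannot be read: the limit of > 48000 nM in this assay, at which 2 of the 3 values shown sit.

As far as these compounds go, how far either sulfur compound lies past the limit stays unknown, so methylsulfanyl and sulfanyl cannot be ranked against each other in this assay. Also open, from the compounds shown here alone, is whether an amine or a methoxy group on this aromatic carbon would match or improve on compound 1, at 16000 nM, or whether the loss extends beyond the two sulfur groups.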